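Working notes: bromo on compound 2

The compounds below may be only part of what the source reports. "The series", "measured", "known", "first", "only" and "open" are said of these compounds alone.

Measured in a functional assay on MCF7 cells (Homo sapiens) for antiproliferative activity, read by MTT assay, with a stated time of 72 h; on this read-out higher numbers stand for weaker inhibition and lower numbers for stronger inhibition:
- compound 1 `O=C1Nc2c(F)cccc2/C1=C1/Nc2ccccc2C1=O`: 44800 nM
- compound 2 `O=C1Nc2ccccc2/C1=C1/Cc2ccccc2C1=O`: 70200 nM

Among the measured compounds shown here, compound 2, at 70200 nM, lies within the scatter of compound 1, the only other measured compound, so the two cannot be ranked. Compound 3 `O=C1Nc2ccc(Br)cc2/C1=C1/Cc2ccccc2C1=O` carries bromo in place of hydrogen on an aromatic carbon of compound 2 (bromo in place of hydrogen on an aromatic carbon). For the measured compounds named here, no measured pair shows this change, so the following is expectation only. A moderate strengthening of inhibition is expected, though a result within the scatter remains possible. The estimated step is a 2.3-fold lower number from compound 2 to compound 3 (0.37 log units; beyond the scatter). For compound 3 the estimated value is 30000 nM, with an expected range of 9000 nM to 80000 nM.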

Compound 3, half-maximal inhibitory concentration: 65200 nM
For compound 3 the middle estimate is 2.2-fold (0.34 log units) below the measured one, and the stated range covers the measured number.
By their numbers in this assay, from the lowest: compounds 1, 3 and 2 (each within the scatter of the next).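

In this assay, among the compounds shown here, bromo in place of hydrogen on an aromatic carbon gives a 1.1-fold lower number from compound 2 to compound 3 (0.03 log units; within the scatter) as the first single-place step. At this position, meta to a fused ring and para to a fused ring, the step lies within the scatter, so bromo does not separate the two compounds on this read-out. Nothing available explains this result.

On these data alone, it remains open whether an amine or a carboxylic acid at this position would give a step beyond the scatter. As far as these compounds go, the effect of bromo at other aromatic carbons of the shared core also remains open.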